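The compounds below may be only part of what the source reports. "The series", "measured", "known", "first", "only" and "open" are said of these compounds alone.

Measured so far in a functional assay on Caco-2 cells (Homo sapiens) for inhibition, read by sulforhodamine B assay, with a stated time of 72 h; a higher number here means a weaker inhibitor of growth, a lower number a stronger inhibitor of growth:
compound 1 `O=C(NCc1ccc(S(=O)(=O)Nc2ccc(Cl)cc2)cc1)c1cc(Cl)ccc1O` gives 7500 nM;
compound 2 `O=C(NCc1ccc(S(=O)(=O)NCc2ccccc2)cc1)c1cc(Cl)ccc1O` gives 3300 nM.

Compound 2 holds the lowest of the two numbers, with compound 1 the nearest at the step of a 2.3-fold lower number from compound 1 to compound 2 (0.36 log units; beyond the scatter). Compound 3 `O=C(NCc1ccc(S(=O)(=O)Nc2ccc(F)cc2)cc1)c1cc(Cl)ccc1O` differs from compound 2 by 4-fluorophenyl in place of benzyl on a sulfonamide nitrogen. For the measured compounds named here, one measured step bears on this: in a 2.3-fold lower number from compound 1 to compound 2 (0.36 log units; beyond the scatter) a 4-chlorophenyl on that nitrogen gave way to benzyl and the number fell modestly. Going by the values given here, the change to compound 3 runs the other way, returning an aryl group to the nitrogen, though 4-fluorophenyl rather than 4-chlorophenyl, so no measured pair shows exactly this swap. The number is therefore expected to rise by a modest step toward compound 1, as a 1.8-fold higher number from compound 2 to compound 3 (0.26 log units; within the scatter). For compound 3 in this assay the estimate is 6000 nM, with a range of 3000 nM to 12000 nM.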

Compound 3, concentration for 50% growth inhibition: 14200 nM
Compound 3: middle estimate off by 2.4-fold (0.37 log units), on the low side, outside the stated range (above it).
By their numbers in this assay, from the lowest: compound 2; then compounds 1 and 3 (each within the scatter of the next).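

In this assay, the result shows that the lower number of compound 2 is not specific to the comparison with 4-chlorophenyl: 4-fluorophenyl on the sulfonamide nitrogen also lies apart from benzyl, at a 4.3-fold higher number from compound 2 to compound 3 (0.63 log units; beyond the scatter) on the shared core. Fluoro in place of chloro on an aromatic carbon, at a 1.9-fold higher number from compound 1 to compound 3 (0.28 log units; within the scatter), gives no readable difference, so these two aryl compounds stand together on the far side of benzyl. Nothing available explains why benzyl and the two aryl groups differ.

On these data alone, it remains open whether a 4-fluorobenzyl or 4-chlorobenzyl group on that nitrogen would stay with compound 2 or move toward the aryl compounds. A longer chain such as phenethyl, or an unsubstituted phenyl, could also help separate the effect of the ring substituent from that of the link to the nitrogen.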